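Hydroxy to trifluoromethyl on an acetylated core

The compounds below may be only part of what the source reports. "The series", "measured", "known", "first", "only" and "open" are said of these compounds alone.

Measured compounds:
Compound 1 `O=C(Nc1ccccc1C(F)(F)F)C1CCc2ccccc2N1`, 57600 nM
Compound 2 `CCCC(=O)N1c2ccccc2CCC1C(=O)Nc1ccccc1C(F)(F)F`
Compound 3 `CC(=O)N1c2ccccc2CCC1C(=O)Nc1ccccc1O`, 50700 nM

In a functional assay on ACHN cells (Homo sapiens) for cytotoxicity, read by sulforhodamine B assay, with a stated time of 72 h (a higher number here means a weaker inhibitor of growth, a lower number a stronger inhibitor of growth), compound 1 gives 57600 nM. Compound 2 reaches only the assay limit of > 70000 nM, so no number is known for it. Compound 3 gives 50700 nM, and this sits within the scatter of compound 1; no order between the two can be read from it.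

The step from compound 3 to compound 4 `CC(=O)N1c2ccccc2CCC1C(=O)Nc1ccccc1C(F)(F)F` is trifluoromethyl in place of hydroxy on an aromatic carbon. Among the compounds with values here, no measured step covers this exchange directly. Within the data shown here, the only measured step, an at least 1.2-fold higher number from compound 1 to compound 2 (0.08 log units; that floor lies within the scatter), concerns the group on the nitrogen and ends at a limit (the limit of > 70000 nM in this assay, at which 1 of the 3 values shown sits), so it speaks only to the acylated core and not to the anilide. Compound 1 and compound 3 differ in two places, so their values show only that both lie in the same weak region.

With all three values weak and one at the limit, compound 4 is expected to give 65000 nM, between 30000 nM and 150000 nM, an estimated step of a 1.3-fold higher number from compound 3 to compound 4 (0.11 log units; within the scatter), with a fair chance of only a limit.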

Compound 4, concentration for 50% growth inhibition: > 80000 nM
Compound 4: no number, only a limit; the forecaster's own chance of this, stated with the estimate: 45%; middle value at least 1.2-fold (0.09 log units) away from the limit.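

Compound 4 yields no number in this assay, only a limit of the assay: the limit of > 80000 nM in this assay, at which 1 of the 4 values shown sits.

Trifluoromethyl in place of hydroxy on this aromatic carbon, ortho to a large group, gives an at least 1.5-fold higher number from compound 3 to compound 4 (0.19 log units; that floor lies within the scatter), so this exchange brings no gain in growth inhibition, and the true size of the step stays unknown. Acetyl in place of hydrogen on the nitrogen likewise brings no gain, with an at least 1.3-fold higher number from compound 1 to compound 4 (0.14 log units; that floor lies within the scatter), and this adds a second acyl group to the propylcarbonyl already seen on that nitrogen.

The step between the two limits, compound 2 and compound 4, cannot be read. Still open, on these data alone, is whether an amine or a carboxylic acid on this aromatic carbon would give a stronger inhibitor of growth than the hydroxy of compound 3.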